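Working notes: hexyl for piperidin-1-yl, compound 3 to compound 4

The source may hold more compounds than are shown below. What is called first, only, known or untested is meant among the compounds shown, and "the series" means these compounds.

Measured so far:
compound 1 `C[C@H](NC(=O)/C(C#N)=C/c1cccc(Br)n1)c1ccc(Br)cc1` — 1500 nM
compound 2 `N#C/C(=C\c1cccc(Br)n1)C(=O)N[C@@H]1CCc2ccccc21` — 2000 nM
compound 3 `N#C/C(=C\c1ccc(N2CCCCC2)cc1)C(=O)NC(c1ccccc1)C1CC1` — > 10000 nM

In a functional assay on MM1 cells (Homo sapiens) for antiproliferative activity, read by MTT assay, with a stated time of 72 h (a higher number here means a weaker inhibitor, a lower number a stronger inhibitor), compound 1 gives 1500 nM. Compound 2 gives 2000 nM in this assay, and the two values lie within the scatter of each other. For compound 3 this assay reports only a limit, > 10000 nM. That is the limit of > 10000 nM in this assay, at which 1 of the 3 values shown sits, so compound 3 is the one of the three with no number, and it stands apart from compounds 1 and 2, which both returned numbers.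

Compound 4 `CCCCCCc1ccc(/C=C(\C#N)C(=O)NC(c2ccccc2)C2CC2)cc1` differs from compound 3 by hexyl in place of piperidin-1-yl on an aromatic carbon. Among the measured compounds shown here, no pair of measured compounds shows this change, so its size and direction cannot be read from the data. With compound 3 at the limit, compound 4 is expected to stay near that limit, with the step that the limit leaves unreadable from compound 3 to compound 4 expected to be none beyond the scatter. Compound 4 is therefore estimated at 12000 nM in this assay, with a range from 4000 nM to 40000 nM, and a fair chance that only a limit is reported again.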

Compound 4, half-maximal inhibitory concentration: > 10000 nM
Compound 4 was reported as a limit; the forecaster's own chance of this, stated with the estimate: 55%; the middle value does not contradict the limit.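

Compound 3 and compound 4 both stand as limits in this assay, so no step between them can be read: the limit of > 10000 nM in this assay, at which 2 of the 4 values shown sit.

The compounds shown leave open whether hexyl in place of piperidin-1-yl on an aromatic carbon changes antiproliferative activity at all, and in which direction.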